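A few compounds are considered here, and "the series" means these few. Any claim that something is new, unique, unknown or untested is made for them only; others in the source may bear on it.

In a functional assay on MDA-MB-231 cells (Homo sapiens) for antiproliferative activity, read by CellTiter-Glo, with a stated time of 96 h (on this read-out higher numbers stand for weaker inhibition and lower numbers for stronger inhibition), compound 1 `COc1ccc(-c2nsc3c2NC(=O)CC3c2cccc(OC)c2)cc1` gives 1390 nM and compound 2 `COc1ccc(-c2nsc3c2NC(=O)CC3c2cccc(Cl)c2)cc1` gives 1620 nM. Compound 3 `COc1ccc(-c2nsc3c2NC(=O)CC3c2cccc(F)c2)cc1` gives > 2000 nM, which is a limit of the assay and not a number. Compound 4 `COc1ccc(-c2nsc3c2NC(=O)CC3c2ccc(F)cc2)cc1` has not been measured yet. It carries 4-fluorophenyl in place of the 3-fluorophenyl of compound 3, on a saturated ring carbon: 4-fluorophenyl in place of 3-fluorophenyl on a saturated ring carbon. The measured steps bear on this change only indirectly, since each swaps one group for another on an aromatic carbon and none moves the fluoro group. They are a 1.2-fold higher number from compound 1 to compound 2 (0.07 log units; within the scatter), an at least 1.4-fold higher number from compound 1 to compound 3 (0.15 log units; that floor lies within the scatter) and an at least 1.2-fold higher number from compound 2 to compound 3 (0.09 log units; that floor lies within the scatter). None of them is shown to go beyond the scatter, so no step beyond the scatter is expected in this assay, and no direction can be favoured with confidence. The expected change is small, and the estimate amounts to a step that the limit leaves unreadable from compound 3 to compound 4. For compound 4 the estimated value is 2300 nM, with an expected range of 1200 nM to 4500 nM.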

Compound 4, half-maximal inhibitory concentration: > 2000 nM
Compound 4 ended at the assay's limit; the forecaster's own chance of this, stated with the estimate: 50%; the middle value does not contradict the limit.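

In this assay compound 4 gives > 2000 nM, which is a limit of the assay and not a number. Moving the fluoro group, from 3-fluorophenyl to 4-fluorophenyl on the saturated ring carbon, therefore yields no readable step, because compound 3 and compound 4 both sit at the same limit: the limit of > 2000 nM in this assay, at which 2 of the 4 values shown sit. The two readable steps are an at least 1.2-fold higher number from compound 2 to compound 4 (0.09 log units; that floor lies within the scatter) and an at least 1.4-fold higher number from compound 1 to compound 4 (0.15 log units; that floor lies within the scatter), so 4-fluorophenyl is not shown to differ from 3-chlorophenyl or 3-methoxyphenyl at this place.

Going by these compounds, whether the position of the fluoro group matters at all stays open, since neither of the two fluoro compounds has a true value here. Also open, on these data alone, is whether an amine or a carboxylic acid in place of the fluoro group would shift the result beyond the scatter.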